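The compounds below may be only part of what the source reports. "The series", "measured", "known", "first", "only" and "open" are said of these compounds alone.

In a functional assay on WiDr cells (Homo sapiens) for inhibition, read by sulforhodamine B assay, with a stated time of 48 h (on this read-out lower numbers stand for stronger inhibition of growth and higher numbers for weaker inhibition of growth), the measured compounds are:
compound 1 `COC(=O)[C@@]1(C)CCC=C2[C@@H]1CC[C@@H](C)[C@]2(C)Cc1c[nH]c2ccc(F)cc12` gives 8000 nM
compound 2 `COC(=O)[C@@]1(C)CCC=C2[C@@H]1CC[C@@H](C)[C@]2(C)Cc1c[nH]c2ccc(OC)cc12` gives 5700 nM
compound 3 `COC(=O)[C@@]1(C)CC[C@@H]2C3=C1CC[C@@H](C)[C@]3(C)C[C@@H]1c3cc(F)ccc3N[C@H]21` gives 32000 nM

Compound 4 `COC(=O)[C@@]1(C)CC[C@@H]2C3=C1CC[C@@H](C)[C@]3(C)C[C@@H]1c3cc(OC)ccc3N[C@H]21` has not yet been measured. It differs from compound 3 by one change, (methoxy in place of fluoro on an aromatic carbon). The same kind of change, (methoxy in place of fluoro on an aromatic carbon), separates compound 1 from compound 2, where it gave a 1.4-fold lower number from compound 1 to compound 2 (0.15 log units; within the scatter). The two changes sit in different surroundings: in compound 1 the ring belongs to a fused or bridged system of two rings, in compound 3 to one of five rings. How the core of compound 1 and the core of compound 3 differ is not broken down here. Resting on the step from compound 1 to compound 2, the step from compound 3 to compound 4 is expected to be a 1.4-fold lower number from compound 3 to compound 4 (0.14 log units; within the scatter). Compound 4 is therefore estimated at 23000 nM, between 10000 nM and 55000 nM.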

Compound 4, concentration for 50% growth inhibition: 25000 nM
Beside the measured number, compound 4's estimate is 1.1-fold (0.04 log units) below it, and the stated range covers the measured number.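

In this assay, putting methoxy in place of fluoro on the core of compound 3 gives a 1.3-fold lower number from compound 3 to compound 4 (0.11 log units; within the scatter). Set beside the earlier step, the change reads the same on both cores: the same change on two cores in this assay, a 1.4-fold lower number (0.15 log units; within the scatter) from compound 1 to compound 2 and a 1.3-fold lower number (0.11 log units; within the scatter) from compound 3 to compound 4, 1.1-fold (0.04 log units) apart, within the scatter of two such steps. This shows that on these two cores the swap leaves growth inhibition within the usual scatter, but because both steps are so small, it does not show that a larger effect would carry from one core to the other, or that other cores would behave alike.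

The compounds shown carry only fluoro or methoxy at this place. As far as these compounds go, how an amine or a carboxylic acid on that aromatic carbon would read remains open.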